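This account rests on a few compounds, and the source may have more. Where it says the series, first, only, none or still open, it means among the compounds named here.

Measured so far:
Compound 1, `C=CCn1c(=N)sc2cc(OC(F)(F)F)ccc21`: 7 mg/kg
Compound 3, `CSCCn1c(=N)sc2cc(OC(F)(F)F)ccc21`: 1 mg/kg
Compound 2, `N=c1sc2cc(OC(F)(F)F)ccc2n1CCS(=O)(=O)O`: a limit, > 10 mg/kg

In a functional assay on the whole organism with Rattus norvegicus as the target (a higher number here means that more compound is needed for the effect, a lower number that less compound is needed), compound 3 stands with the lowest number of the values shown; the step of a 7.0-fold lower number from compound 1 to compound 3 (0.85 log units; beyond the scatter) lies beyond the scatter. For compound 2 the assay reports only a limit, (the limit of > 10 mg/kg in this assay, at which 1 of the 3 values shown sits). The step of an at least 10-fold lower number from compound 2 to compound 3 (1.00 log units; beyond the scatter) is likewise beyond the scatter.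

Compound 4, `CN(C)CCn1c(=N)sc2cc(OC(F)(F)F)ccc21`, differs from compound 3 by dimethylamino in place of methylsulfanyl on a saturated chain carbon, two bonds along the chain from an aromatic nitrogen. For the measured compounds named here, no measured step makes this exchange; the steps of a 7.0-fold lower number from compound 1 to compound 3 (0.85 log units; beyond the scatter) and an at least 10-fold lower number from compound 2 to compound 3 (1.00 log units; beyond the scatter) show only that the group on this chain carbon can move the number substantially. Compound 4 is therefore expected to give a modest step of a 2.0-fold higher number from compound 3 to compound 4 (0.30 log units; within the scatter). Compound 4 is estimated at 2 mg/kg, within 0.7 mg/kg to 7 mg/kg.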

Compound 4, dose for half-maximal effect: 2.3 mg/kg
Compound 4: middle estimate off by 1.2-fold (0.06 log units), on the low side; measured number inside the range.
By their numbers in this assay, from the lowest: compound 3; then compound 4; then compound 1. At a limit, above all of these: compound 2.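

In this assay a chain-end dimethylamino raises the number only modestly compared with methylsulfanyl (a 2.3-fold higher number from compound 3 to compound 4 (0.36 log units; beyond the scatter)). It still gives a lower number than vinyl (a 3.0-fold lower number from compound 1 to compound 4 (0.48 log units; beyond the scatter)), so this gain at the position is not confined to methylsulfanyl. Compound 2 gives only a limit, so the step to compound 4 (an at least 4.3-fold lower number from compound 2 to compound 4 (0.63 log units; beyond the scatter)) is a floor: the limit of > 10 mg/kg in this assay, at which 1 of the 4 values shown sits.

The compounds shown leave open how diethylamino or a primary amine would compare with dimethylamino on this chain carbon. They also leave open whether a carboxylic acid would track sulfo, and what a longer chain would do.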